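Adding a Second Chloro Group to Compound 1

The compounds below may be only part of what the source reports. "The series", "measured", "known", "first", "only" and "open" are said of these compounds alone.

Compound 1 `NC1=NC2(CCSCC2)N(OCCCOc2cccc(Cl)c2)C(N)=N1` was tested in an assay on isolated protein for inhibition of Dihydrofolate reductase (Homo sapiens), read by spectrophotometry, using NADPH, with stated times of 5 s and 6 min, tested at 5 uM (a lower number here means a weaker effect, a higher number a stronger effect of the compound at the concentration tested), where compound 1 gives 88.3%. Of the two numbers recorded this is the highest, yet compound 3 `NC1=NC2(CCOCC2)N(OCCCOc2cccc(Br)c2)C(N)=N1` gives 86.7%, and that gap lies within the usual scatter. For compound 2 `NC1=NC2(CCOCC2)N(OCCCOc2ccc(Cl)c(Cl)c2)C(N)=N1` the assay reports only a limit, > 90%, rather than a number (the limit of > 90% in this assay, at which 1 of the 3 values shown sits). Within the data shown here, the single measured step between close neighbours is a number at least 3.3 percentage points lower from compound 2 to compound 3 (that floor lies within the scatter); it starts at that limit, so only its floor is known.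

Compound 4 `NC1=NC2(CCSCC2)N(OCCCOc2ccc(Cl)c(Cl)c2)C(N)=N1` has not yet been measured. It differs from compound 1 in one place, (chloro in place of hydrogen on an aromatic carbon), on an aromatic carbon of the aryl group. This is the same exchange of aryl groups seen between compound 3 and compound 2, taken in the opposite direction, on the core of compound 1. Because the step of a number at least 3.3 percentage points lower from compound 2 to compound 3 (that floor lies within the scatter) was downward on removing the second halogen, the step for compound 4 in this assay is expected to run upward, of modest size and possibly reaching the limit. Compound 4 is therefore estimated at 91%, within a range of 85% to 96%. That estimate corresponds to an expected step of a number 2.7 percentage points higher from compound 1 to compound 4 (within the scatter).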

Compound 4, a percentage reported as inhibition, at one concentration (the size of the read-out at that concentration, not a potency): 88.4%
For compound 4 the middle estimate is 2.6 percentage points above the measured one; the measured number falls inside the stated range.
By their numbers in this assay, from the lowest: compounds 3, 1 and 4 (each within the scatter of the next). At a limit, above all of these: compound 2.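

In this assay, going from 3-chlorophenyl to 3,4-dichlorophenyl on the core of compound 1 puts a chloro group on the aromatic carbon ortho to the existing chloro group and para to a large group, and it gives a number 0.1 percentage points higher from compound 1 to compound 4 (within the scatter). Among these compounds, this is the first step involving the 3,4-dichlorophenyl group whose size can be read in full, and it shows that on this core the added chloro group yields a number that cannot be told apart from that of its parent. Compound 2, which carries the same 3,4-dichlorophenyl group on a different core, has only a limit and not a number, so the earlier step gave no size and the comparison with it stays open: the limit of > 90% in this assay, at which 1 of the 4 values shown sits.

All of these read-outs come from a single concentration, so the compounds shown leave open whether compound 1 and compound 4 would also stand together in a measure of potency. Also open, going by these compounds, is whether a methoxy group or a carboxylic acid on this aromatic carbon, or a longer chain between the aryl group and the core, would give a number set apart from that of compound 1.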